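Swapping methoxy for amino on a biphenyl diol scaffold

This account rests on a few compounds, and the source may have more. Where it says the series, first, only, none or still open, it means among the compounds named here.

Of the compounds shown here, three have been tested in a functional assay on MCF7 cells (Homo sapiens) for cytotoxicity, read by MTT assay, with a stated time of 3 days (on this read-out higher numbers stand for weaker inhibition and lower numbers for stronger inhibition), so far. Compound 1, `COc1ccccc1-c1ccccc1O`, reaches only the assay's limit: in this assay compound 1 gives > 100 ug/mL, a limit rather than a number. Compound 2, `Nc1ccccc1-c1cccc(O)c1`, gives 16 ug/mL. Compound 3, `COc1cccc(-c2cccc(O)c2)c1`, gives 33 ug/mL, the higher of the two numbers. The gap between compound 3 and compound 2 lies beyond the usual scatter of this read-out.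

Compound 4, `Nc1cccc(-c2cccc(O)c2)c1`, has not yet been measured. It differs from compound 3 in one place: amino in place of methoxy on an aromatic carbon. The change is small, one atom in place of two, and it brings a hydrogen-bond donor that compound 3 lacks at that spot. Among the compounds with values here, compound 2, the only measured compound carrying an amino group, sits at 16 ug/mL, a number lower than compound 3. On that basis a modest move toward stronger inhibition is expected, though one that may well stay within the scatter. Compound 4 is estimated to give 20 ug/mL in this assay, between 8 ug/mL and 50 ug/mL, an expected step of a 1.7-fold lower number from compound 3 to compound 4 (0.22 log units; within the scatter).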

Compound 4, half-maximal inhibitory concentration: 99 ug/mL
Compound 4: the middle estimate sits 5.0-fold (0.69 log units) below what was measured; measured number above the stated range.
By their numbers in this assay, from the lowest: compound 2; then compound 3; then compound 4. At a limit, above all of these: compound 1.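

In this assay, putting amino in place of methoxy on this aromatic carbon gives a 3.0-fold higher number from compound 3 to compound 4 (0.48 log units; beyond the scatter), so at this position the swap weakens inhibition rather than strengthening it. The smaller group, with the hydrogen-bond donor it brings, offers no gain here, and of these two groups methoxy is the better one on this core. Compound 4 also lands close to the top of what this assay can report, leaving little room to size any further weakening: the limit of > 100 ug/mL in this assay, at which 1 of the 4 values shown sits.

A single step cannot show whether the change reflects losing methoxy or gaining amino. Comparing a methyl group, a fluorine atom or an ethoxy group at the same carbon would help separate the two, and would show how much this position tolerates.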